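A few compounds are considered here, and "the series" means these few. Any claim that something is new, unique, unknown or untested is made for them only; others in the source may bear on it.

Series notes. Compound 1, `COc1ccc(-c2ssc(=O)c2-c2cc(OC)c(OC)c(OC)c2)cc1O`, gives 3110 nM in a functional assay on SGC-7901 cells (Homo sapiens) for antiproliferative activity, read by MTT assay, with a stated time of 72 h; on this read-out higher numbers stand for weaker inhibition and lower numbers for stronger inhibition. Compound 2, `COc1ccc(-c2ssc(=O)c2-c2cc(OC)c(OC)c(OC)c2)cc1N`, gives 172 nM in this assay. The change between them, (amino in place of hydroxy on an aromatic carbon), brought an 18-fold lower number from compound 1 to compound 2 (1.26 log units; beyond the scatter). Compound 3, `COc1ccc(-c2ss/c(=N/O)c2-c2cc(OC)c(OC)c(OC)c2)cc1O`, gives 200 nM in this assay; the difference between the core of compound 3 and the core of compound 1 is not broken down here, and the two values alone show compound 3 at a lower number than compound 1, while compound 3 and compound 2 lie within the scatter of each other. Compound 4, `COc1ccc(-c2ss/c(=N/O)c2-c2cc(OC)c(OC)c(OC)c2)cc1N`, is not yet measured. It differs from compound 3 by amino in place of hydroxy on an aromatic carbon, the same change as that from compound 1 to compound 2, made at the same place. The change has been seen only once, and on a different core. For compound 4 the expected step is a 4.4-fold lower number from compound 3 to compound 4 (0.65 log units; beyond the scatter), smaller than the earlier one, because compound 3 already gives 200 nM. Compound 4 is therefore estimated at 45 nM, with a likely range from 10 nM to 200 nM.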

Compound 4, half-maximal inhibitory concentration: 4300 nM
Estimate against measurement, compound 4: 96-fold (1.98 log units) below, and the stated range ends below it.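

On the core of compound 3 the change gave a 22-fold higher number from compound 3 to compound 4 (1.33 log units; beyond the scatter), opposite in direction to the earlier step, so in this assay the result of amino in place of hydroxy on this aromatic carbon depends on the core that carries it: the same change on two cores in this assay, an 18-fold lower number (1.26 log units; beyond the scatter) from compound 1 to compound 2 and a 22-fold higher number (1.33 log units; beyond the scatter) from compound 3 to compound 4, 390-fold (2.59 log units) apart, beyond the scatter of two such steps

The change therefore cannot be carried from one core to the other in this series as a fixed step, and not even its direction carries over. These two pairs do not show why the direction reverses, nor which outcome a third core would follow.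

Open, from the compounds shown here alone, is whether the reversal belongs to the hydroxy and amino pair alone or also appears with other groups at this place, such as a methylamino group, an acetamide or a fluorine atom. Also open, going by these compounds, is whether a plain hydrogen at this place would side with hydroxy or with amino on each of the two cores.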